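Compound 3 to compound 4: swapping the aryl amide group

The compounds below may be only part of what the source reports. "The series", "measured", "known", "first", "only" and "open" are said of these compounds alone.

Values in a functional assay on HepG2 cells (Homo sapiens) for inhibition, read by MTT assay, with a stated time of 72 h (a higher number here means a weaker inhibitor, a lower number a stronger inhibitor), so far:
- compound 1 `O=C(Nc1ccccc1)C1CCN(C/C=C/c2ccccc2)CC1` gives 90900 nM
- compound 2 `CCc1ccc(NC(=O)C2CCN(C/C=C/c3ccccc3)CC2)cc1` gives 23300 nM
- compound 3 `O=C(Nc1cccc(Br)c1)C1CCN(C/C=C/c2ccccc2)CC1` gives 19200 nM

Compound 3 lies within the scatter of compound 2, with a 1.2-fold lower number from compound 2 to compound 3 (0.08 log units; within the scatter) as the step. Both stand beyond the scatter from compound 1, and for compound 3 that step is a 4.7-fold lower number from compound 1 to compound 3 (0.68 log units; beyond the scatter) in size.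

The next change leads to compound 4 `N#Cc1ccc(NC(=O)C2CCN(C/C=C/c3ccccc3)CC2)cc1` and is 4-cyanophenyl in place of 3-bromophenyl on an amide-type nitrogen.

Within the data shown here, three measured steps bear on it. Adding a substituent to the unsubstituted phenyl gave modest steps, a 3.9-fold lower number from compound 1 to compound 2 (0.59 log units; beyond the scatter) and a 4.7-fold lower number from compound 1 to compound 3 (0.68 log units; beyond the scatter) in turn. Among the measured compounds shown here, the exchange of one substituted phenyl for another, a 1.2-fold lower number from compound 2 to compound 3 (0.08 log units; within the scatter), is the closest precedent and stayed within the scatter. For the measured compounds named here, no measured compound carries a nitrile, so the range stays wide.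

In this assay no change beyond the scatter is expected, and the estimated step is a 1.3-fold higher number from compound 3 to compound 4 (0.11 log units; within the scatter) in size.

For compound 4 the estimated value is 25000 nM, with an expected range from 9000 nM to 80000 nM in this measurement.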

Compound 4, half-maximal inhibitory concentration: 38300 nM
Compound 4: the middle estimate sits 1.5-fold (0.19 log units) below what was measured; low and high end bracket the measured number.
By their numbers in this assay, from the lowest: compounds 3, 2 and 4 (each within the scatter of the next); then compound 1.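

With the nitrile, the substituted phenyl groups on the amide-type nitrogen still form one band, with a 2.0-fold higher number from compound 3 to compound 4 (0.30 log units; within the scatter) and a 1.6-fold higher number from compound 2 to compound 4 (0.22 log units; within the scatter), so this swap, like the earlier exchange of bromo and ethyl groups, separates nothing among them. The lower number relative to the unsubstituted phenyl of compound 1 also extends to a third substituent, with a 2.4-fold lower number from compound 1 to compound 4 (0.38 log units; beyond the scatter), so it is not confined to ethyl and bromo, and none of the compounds shown goes against it. No supporting data are available to explain this shared shift.

Going by these compounds, whether an amine or a carboxylic acid on the same phenyl ring would stay in this band remains open. So does whether these substituents would behave alike after a change elsewhere in the shared core.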